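From compound 3 to compound 4: exchange on the amide nitrogen

The source may hold more compounds than are shown below. What is called first, only, known or untested is meant among the compounds shown, and "the series" means these compounds.

In an ADME assay on MT4 cells (Homo sapiens) for cytotoxicity, read by MTT assay (on this read-out higher numbers stand for lower toxicity in this test and lower numbers for higher toxicity in this test), compound 1 `Cc1cc(C)cc(S(=O)(=O)c2c(C(=O)NCC(=O)NC(C)c3ccccc3)[nH]c3ccc(Cl)cc23)c1` gives 29400 nM as its value and compound 2 `Cc1cc(C)cc(S(=O)(=O)c2c(C(=O)NCC(=O)NC(C)c3ccncc3)[nH]c3ccc(Cl)cc23)c1` gives 47000 nM as its value. The measured step between them is a 1.6-fold higher number from compound 1 to compound 2 (0.20 log units; within the scatter) and no order is drawn from it. Compound 3 `Cc1cc(C)cc(S(=O)(=O)c2c(C(=O)NCC(=O)NCc3ccccc3F)[nH]c3ccc(Cl)cc23)c1` reports only a limit, > 47300 nM and no number. The two steps that reach it are an at least 1.6-fold higher number from compound 1 to compound 3 (0.20 log units; that floor lies within the scatter) and a number no lower from compound 2 to compound 3 (the limit leaves the size open) and neither shows a size beyond the scatter.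

Compound 4 `Cc1cc(C)cc(S(=O)(=O)c2c(C(=O)NC(C)c3cc(F)cc(F)c3)[nH]c3ccc(Cl)cc23)c1` differs from compound 3 by 1-(3,5-difluorophenyl)ethyl in place of ((2-fluorobenzyl)carbamoyl)methyl on an amide-type nitrogen and so carries 1-(3,5-difluorophenyl)ethyl in place of ((2-fluorobenzyl)carbamoyl)methyl. Among the compounds with values here, no measured step makes this exchange, so the steps above bear on it only loosely. Within the data shown here, compound 1 at 29400 nM and compound 2 at 47000 nM mark the only numbers available, so no step beyond the scatter is expected in this assay and any lean is towards a lower number. The expected size is an at least 1.5-fold lower number from compound 3 to compound 4 (0.19 log units; that floor lies within the scatter) as an estimate set against a limit. Compound 4 is estimated at 30000 nM with an expected range from 10000 nM to 60000 nM in this read-out.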

Compound 4, half-maximal cytotoxic concentration: > 49700 nM
Compound 4: a limit, no number (the forecaster's own chance of this, stated with the estimate: 35%); middle value at least 1.6-fold (0.21 log units) from the limit.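

Compound 4 ends in a limit and not a number, and the step from compound 3, also a limit, cannot be read: the limit of > 49700 nM in this assay, at which 1 of the 4 values shown sits.

Neither readable step shows a size beyond the scatter, an at least 1.6-fold higher number from compound 1 to compound 4 (0.22 log units; that floor lies within the scatter) and an at least 1.0-fold higher number from compound 2 to compound 4 (0.02 log units; that floor lies within the scatter), so no order among these compounds is drawn in this assay. What is new is that 1-(3,5-difluorophenyl)ethyl, with 0 hydrogen-bond donors and 0 hydrogen-bond acceptors, also gives a limit on the amide-type nitrogen, so the ((2-fluorobenzyl)carbamoyl)methyl chain is not required for a limit in this test.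

Where the true values of compound 3 and compound 4 lie remains open. Also open, going by these compounds, is whether a chain ending in an amine or a carboxylic acid on this amide-type nitrogen would give a number instead of a limit.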